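Swapping a benzyloxy group for a methoxycarbonyl group

The source may report more compounds than this note shows. Statements on the series, on what has been measured and on what is new or still open speak of the compounds shown alone.

Three ureas sharing one core have been measured in an assay on microsomes for inhibition of acyl-CoA:cholesterol acyltransferase (Oryctolagus cuniculus); a higher number here means a weaker inhibitor, a lower number a stronger inhibitor. Compound 1 `Cc1cccc(C2(CNC(=O)Nc3c(C(C)C)cccc3C(C)C)CCCC2)c1` gives 15 nM, compound 2 `CC(C)c1cccc(C(C)C)c1NC(=O)NCC1(c2ccc(C(C)(C)C)cc2)CCCC1` gives 63 nM, and compound 3 `CC(C)c1cccc(C(C)C)c1NC(=O)NCC1(c2cccc(OCc3ccccc3)c2)CCCC1` gives 30 nM. Compound 3 thus has the second highest of the three numbers: its nearest neighbour is compound 1, within the scatter, while compound 2 lies beyond the scatter on the higher side, as the step of a 4.2-fold higher number from compound 1 to compound 2 (0.62 log units; beyond the scatter) also shows.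

Compound 4 `COC(=O)c1cccc(C2(CNC(=O)Nc3c(C(C)C)cccc3C(C)C)CCCC2)c1` differs from compound 3 in one place: methoxycarbonyl in place of benzyloxy on an aromatic carbon. Within the data shown here, the only measured step at this same aromatic carbon is a 2.0-fold higher number from compound 1 to compound 3 (0.30 log units; within the scatter), which stayed within the scatter. Compound 2 changed a different ring and is less informative. Among the measured compounds shown here, with no direct precedent for a methoxycarbonyl group, a small drift is expected, not a large one, so compound 4 is estimated at 40 nM (range 15 nM to 110 nM). That estimate means an expected step of a 1.3-fold higher number from compound 3 to compound 4 (0.12 log units; within the scatter).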

Compound 4, half-maximal inhibitory concentration: 34 nM
Beside the measured number, compound 4's estimate is 1.2-fold (0.07 log units) above it, and the stated range covers the measured number.
By their numbers in this assay, from the lowest: compounds 1, 3, 4 and 2 (each within the scatter of the next, the first and the last beyond it).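

In this assay, benzyloxy, which carries an aromatic ring, and methoxycarbonyl, which carries no ring and brings a double bond outside aromatic rings, cannot be told apart at this aromatic carbon, meta to a large group: the exchange gives a 1.1-fold higher number from compound 3 to compound 4 (0.05 log units; within the scatter) and nothing more. Methyl at the same carbon can now be separated from one of these groups, as a 2.3-fold higher number from compound 1 to compound 4 (0.36 log units; beyond the scatter) shows for methoxycarbonyl, though only modestly. Compound 4 also stays within the scatter of the compound with the 4-(tert-butyl)phenyl group, with a 1.9-fold lower number from compound 2 to compound 4 (0.27 log units; within the scatter) for that exchange, so the two cannot be ranked.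

Nothing available gives a reason for these numbers. From the compounds shown here alone, whether a carboxylic acid or an amine at this aromatic carbon would give a number close to those of compound 3 and compound 4 remains open.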